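Oxime Ester Amides: One Aryl Swap, Three Limits

The source may hold more compounds than are shown below. What is called first, only, known or untested is meant among the compounds shown, and "the series" means these compounds.

Compound 1 `CC1(C)C/C(=N\OC(=O)c2cccc(NC(=O)c3cccc(F)c3)c2)c2c(-c3ccc(F)cc3)noc2C1` carries a 4-fluorophenyl group on its core. In a functional assay on HCC1954 cells (Homo sapiens) for antiproliferative activity, read by MTT assay, with a stated time of 72 h (on this read-out lower numbers stand for stronger inhibition and higher numbers for weaker inhibition), compound 1 gives only a limit of the assay, > 25000 nM. Compound 2 `COc1ccc(-c2noc3c2/C(=N/OC(=O)c2cccc(NC(=O)c4cccc(F)c4)c2)CC(C)(C)C3)cc1OC` differs from compound 1 by 3,4-dimethoxyphenyl in place of 4-fluorophenyl on an aromatic carbon. In this assay compound 2 likewise gives only a limit, > 25000 nM. The step between them, a step that the two limits leave unreadable from compound 1 to compound 2, cannot be read because of the limit of > 25000 nM in this assay, at which 3 of the 3 values shown sit.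

Compound 3 `Nc1cccc(C(=O)Nc2cccc(C(=O)O/N=C3\CCCc4onc(-c5ccc(F)cc5)c43)c2)c1` is built on a different core; the difference between the two cores is not broken down here. In this assay compound 3 also gives only a limit, > 25000 nM.

Compound 4 `COc1ccc(-c2noc3c2/C(=N/OC(=O)c2cccc(NC(=O)c4cccc(N)c4)c2)CCC3)cc1OC` is not yet measured. It differs from compound 3 by 3,4-dimethoxyphenyl in place of 4-fluorophenyl on an aromatic carbon, the same change as that from compound 1 to compound 2, made at the same place. Going by the values given here, because of the limit of > 25000 nM in this assay, at which 3 of the 3 values shown sit, no measured step shows what this change does to the read-out. The expectation for compound 4 therefore rests on nothing more than the fact that compound 1, compound 2 and compound 3 all stop at the same limit, with no number among them. The step is estimated as a step that the limit leaves unreadable from compound 3 to compound 4. Compound 4 is expected to give 30000 nM in this assay, within a range from 8000 nM to 100000 nM, and most probably again only as a limit.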

Compound 4, half-maximal inhibitory concentration: > 25000 nM
Compound 4: no number, only a limit; the forecaster's own chance of this, stated with the estimate: 85%; the middle value lies beyond the limit too.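

In this assay compound 4 gives only a limit (> 25000 nM). Going by these compounds alone, the step between compound 3 and compound 4 therefore cannot be read, and no other new step emerges: (the limit of > 25000 nM in this assay, at which 4 of the 4 values shown sit). The compounds shown leave open what 3,4-dimethoxyphenyl in place of 4-fluorophenyl does to the read-out on either core, and how strongly, if at all, any of these compounds inhibits.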